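Series notes: from compound 2 to compound 3

A few compounds are considered here, and "the series" means these few. Any claim that something is new, unique, unknown or untested is made for them only; others in the source may bear on it.

Measured so far in a functional assay (aorta) with Rattus norvegicus as the target; a lower number here means that less compound is needed, a higher number that more compound is needed for the effect:
- compound 1 `COc1ccc(-c2nc(N=C(N)N)sc2-c2ccc(OC)cc2)cc1` gives 2 uM 
- compound 2 `COc1ccc(-c2nc(CNC(=O)NC(C)C)sc2-c2ccc(OC)cc2)cc1` gives 5.7 uM 

For the measured compounds named here, the only measured step is a 2.9-fold higher number from compound 1 to compound 2 (0.45 log units; beyond the scatter) and it leaves compound 2 with the higher of the two numbers.

Compound 3 `COc1ccc(-c2nc(C(=O)N3CCOCC3)sc2-c2ccc(OC)cc2)cc1` is not yet measured. It keeps the core of compound 2 and carries (morpholin-4-yl)carbonyl in place of ((isopropylcarbamoyl)amino)methyl on an aromatic carbon in a change that brings in one six-membered non-aromatic ring with 2 hetero atoms where the group that leaves has no ring.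

Going by the values given here, one measured step bears on this, and only loosely. Among the compounds with values here, that step, a 2.9-fold higher number from compound 1 to compound 2 (0.45 log units; beyond the scatter), is modest, and no measured compound carries a ring in this place. A small move to a higher number in this assay is therefore expected, and one within the scatter would be no surprise. The estimated step is a 1.6-fold higher number from compound 2 to compound 3 (0.20 log units; within the scatter) on this thin evidence. Compound 3 is expected at 9 uM with an estimated range from 3 uM to 30 uM until its measurement is available.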

Compound 3, concentration for half-maximal effect: < 100 uM
Compound 3: no number, only a limit (the forecaster's own chance of this, stated with the estimate: 10%); the middle value is on the limit's open side.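

In this assay compound 3 gives < 100 uM, which is a limit and not a number, so its steps from compound 2 and from compound 1 cannot be read. The compounds shown leave open how (morpholin-4-yl)carbonyl compares with ((isopropylcarbamoyl)amino)methyl at this place on the shared core, in size and in direction.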